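A Benzyl Swap at the Limit of a Toxicity Test

The source may report more compounds than this note shows. Statements on the series, on what has been measured and on what is new or still open speak of the compounds shown alone.

Three related compounds have been tested in a toxicity assay on MT2 cells (Homo sapiens) for cytotoxicity; on this read-out higher numbers stand for lower toxicity in this test and lower numbers for higher toxicity in this test: compound 1 `Cc1nc(C)c([C@H](OC(C)(C)C)C(=O)O)c(N2CCC(C)(C)CC2)c1-c1ccc2c(c1)CCN(Cc1ccc(F)cc1)C2`, compound 2 `Cc1nc(C)c([C@H](OC(C)(C)C)C(=O)O)c(N2CCC(C)(C)CC2)c1C1=CCN(CCCc2ccc(F)cc2)CC1` and compound 3 `Cc1cccc(F)c1CN1CCc2cc(-c3c(C)nc(C)c([C@H](OC(C)(C)C)C(=O)O)c3N3CCC(C)(C)CC3)ccc2C1`. Compound 1 gives >= 22000 nM, which is a limit of the assay and not a number. Compound 2 gives >= 22000 nM, also a limit. Compound 3 gives >= 24000 nM, again a limit, so it stands with the other two and has no exact number of its own.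

The next compound is compound 4 `Cc1nc(C)c([C@H](OC(C)(C)C)C(=O)O)c(N2CCC(C)(C)CC2)c1-c1ccc2c(c1)CCN(Cc1cccc(F)c1F)C2`, and the change is 2,3-difluorophenyl in place of 2-fluoro-6-methylphenyl on a saturated chain carbon bound to an amine nitrogen in a ring. Here 2,3-difluorophenyl comes in place of 2-fluoro-6-methylphenyl, on a saturated chain carbon bound to an amine nitrogen in a ring.

Within the data shown here, one measured step touches the same place: a step that the two limits leave unreadable from compound 1 to compound 3. That step gives neither a size nor a direction to carry over. No step beyond the usual scatter is therefore expected in this assay, an expectation that rests on compound 3 and its limit of >= 24000 nM. The expected step is a number no higher from compound 3 to compound 4 (the limit leaves the size open). For compound 4 the estimated value is 24000 nM, with an expected range from 14000 nM to 45000 nM, and it will probably be reported only as a limit again.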

Compound 4, half-maximal cytotoxic concentration: >= 24000 nM
Compound 4: a limit, no number; the forecaster's own chance of this, stated with the estimate: 85%; the middle value lies on the limit itself.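

In this assay no new step can be read: compound 1, compound 3 and compound 4 all give limits of the assay and not numbers, so the steps among them have neither a size nor a direction. The compounds shown leave open whether swapping the benzyl group changes toxicity in this test at all.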